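Aryl swaps on the shared core, heading for compound 4

The source may report more compounds than this note shows. Statements on the series, on what has been measured and on what is new or still open speak of the compounds shown alone.

Values in a functional assay on HCT-116 cells (Homo sapiens) for inhibition, read by CCK-8 assay, with a stated time of 48 h (a lower number here means a stronger inhibitor, a higher number a weaker inhibitor), are as follows
- compound 1 `COc1cc(-c2ccnc3cc(-c4ccc(Cl)cc4)nn23)cc(OC)c1OC` gives 3340 nM
- compound 2 `COc1cc(-c2ccnc3cc(-c4cccc(C#N)c4)nn23)cc(OC)c1OC` gives > 10000 nM (a limit of the assay)
- compound 3 `COc1cc(-c2ccnc3cc(-c4ccc5c(ccn5C)c4)nn23)cc(OC)c1OC` gives 39 nM

Compound 3 has the lower of the two exact numbers. Compound 4 `COc1cc(-c2ccnc3cc(-c4ccc5cc[nH]c5c4)nn23)cc(OC)c1OC` carries 1H-indol-6-yl in place of the 1-methyl-1H-indol-5-yl of compound 3 1H-indol-6-yl in place of 1-methyl-1H-indol-5-yl on an aromatic carbon on the same aromatic carbon. Three measured swaps at that carbon bear on this change: an 86-fold lower number from compound 1 to compound 3 (1.93 log units; beyond the scatter) and an at least 250-fold lower number from compound 2 to compound 3 (2.40 log units; beyond the scatter) are large, and an at least 2.9-fold higher number from compound 1 to compound 2 (0.47 log units; beyond the scatter) is at least modest. None exchanges one indolyl group for another, so a smaller step towards a higher number is expected from compound 3 at 39 nM in this series. The estimated step is a 5.1-fold higher number from compound 3 to compound 4 (0.71 log units; beyond the scatter) in this assay here. Compound 4 is estimated at 200 nM with a range from 30 nM to 1500 nM in this assay overall.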

Compound 4, half-maximal inhibitory concentration: 187 nM
Beside the measured number, compound 4's estimate is 1.1-fold (0.03 log units) above it; the range from low to high includes it.
By their numbers in this assay, from the lowest: compound 3; then compound 4; then compound 1. At a limit, above all of these: compound 2.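

In this assay, the exchange of 1-methyl-1H-indol-5-yl for 1H-indol-6-yl gives a 4.8-fold higher number from compound 3 to compound 4 (0.68 log units; beyond the scatter), showing that potency at this position responds to the indolyl group's form. Even so, the 1H-indol-6-yl group stays well ahead of both phenyl groups, with an 18-fold lower number from compound 1 to compound 4 (1.25 log units; beyond the scatter) and an at least 53-fold lower number from compound 2 to compound 4 (1.72 log units; beyond the scatter). The value of compound 2 is a limit of the assay, and its step is only a bound: the limit of > 10000 nM in this assay, at which 1 of the 4 values shown sits.

On these data alone, the swap changes the attachment point and removes the methyl group together, and the share of each in the step stays open. Within the data shown here, a 1H-indol-5-yl group would carry only one of these changes, and its effect remains unknown.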